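The source may report more compounds than this note shows. Statements on the series, on what has been measured and on what is new or still open speak of the compounds shown alone.

Among the measured compounds shown here, in an in vitro ADME assay on microsomes from liver (Homo sapiens) for pharmacokinetics, read by LC-MS, with a stated time of 10 min, tested at 1 uM (a higher number here means faster removal of the compound, a lower number slower removal), compound 1 (`CN1C[C@H](C(=O)Nc2ccccc2)[C@@H](c2ccc(/C=C/C(=O)Nc3ccccc3N)cc2)C1`) gives 7 mL/min/kg and compound 2 (`CN1C[C@H](C(=O)Nc2ccc(Cl)c(Cl)c2)[C@@H](c2ccc(/C=C/C(=O)Nc3ccccc3N)cc2)C1`) gives 14 mL/min/kg as the only other number so far. These two values lie within the scatter of each other, so compound 2 cannot be ranked apart from compound 1. Compound 3 (`Cc1ccc(NC(=O)[C@H]2CN(C)C[C@@H]2c2ccc(/C=C/C(=O)Nc3ccccc3N)cc2)cn1`), not yet measured, carries 6-methylpyridin-3-yl in place of 3,4-dichlorophenyl on an amide-type nitrogen. For the measured compounds named here, the one measured step at that place is a 2.0-fold higher number from compound 1 to compound 2 (0.30 log units; within the scatter) and it brought in 3,4-dichlorophenyl in place of phenyl. Going by the values given here, no measured compound carries a ring with a hetero atom there, so this step is only a loose guide. No change beyond the scatter is therefore expected in this assay for this replacement. The estimated step is a 1.6-fold lower number from compound 2 to compound 3 (0.19 log units; within the scatter) and its direction is tentative. For compound 3 the estimated clearance is 9 mL/min/kg with an expected range of 4 mL/min/kg to 18 mL/min/kg as the working figure.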

Compound 3, clearance: 8 mL/min/kg
Beside the measured number, compound 3's estimate is 1.1-fold (0.05 log units) above it; the measured number falls inside the stated range.
By their numbers in this assay, from the lowest: compounds 1, 3 and 2 (each within the scatter of the next).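

In this assay, among the compounds shown here, the amide-type nitrogen carries a ring with a hetero atom for the first time: 6-methylpyridin-3-yl in place of 3,4-dichlorophenyl gives a 1.8-fold lower number from compound 2 to compound 3 (0.24 log units; within the scatter), and in place of phenyl it gives a 1.1-fold higher number from compound 1 to compound 3 (0.06 log units; within the scatter). Phenyl, 3,4-dichlorophenyl and 6-methylpyridin-3-yl therefore cannot be told apart at this position, whether the ring is of carbon only or holds a hetero atom. No other data bear on this result.

Still open, on these data alone, is whether a group of another type on this nitrogen, such as cyclohexyl or a longer alkyl chain, would give a number beyond the scatter of these three. Also open, as far as these compounds go, is whether a carboxylic acid or an amine on the aromatic ring would do so, and how pyridin-3-yl without the methyl group compares.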